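The source may report more compounds than this note shows. Statements on the series, on what has been measured and on what is new or still open speak of the compounds shown alone.

Working notes on the series, all read in a functional assay on A2780 cells (Homo sapiens) for antiproliferative activity, read by fluorescence, with a stated time of 72 h; on this read-out lower numbers stand for stronger inhibition and higher numbers for weaker inhibition. Compound 3 (`CN1CCC(C(=O)N2Cc3c(NC(=O)c4ccc(F)c(F)c4)n[nH]c3C2(C)C)CC1`) gives 100 nM and compound 2 (`CN1CCC(C(=O)N2Cc3c(NC(=O)c4ccc(Cl)cc4)n[nH]c3C2(C)C)CC1`) gives 120 nM. These two lie within the scatter of each other, as a 1.2-fold lower number from compound 2 to compound 3 (0.08 log units; within the scatter) shows, so compound 3 shares the low end of the three numbers with compound 2. Compound 1 (`CN1CCC(C(=O)N2Cc3c(NC(=O)NCc4ccccc4)n[nH]c3C2(C)C)CC1`) stands well apart at 2680 nM.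

The next structure is compound 4 (`CCCNC(=O)Nc1n[nH]c2c1CN(C(=O)C1CCN(C)CC1)C2(C)C`), with the change propylamino in place of 3,4-difluorophenyl on a carbonyl carbon. Compound 1 is the closest measured comparison, as it carries benzylamino at that place. Two large steps bear on the change: a 27-fold lower number from compound 1 to compound 3 (1.43 log units; beyond the scatter) and a 22-fold lower number from compound 1 to compound 2 (1.35 log units; beyond the scatter). Compound 4 runs the same kind of exchange in the opposite direction, though with propylamino rather than benzylamino. Among the measured compounds shown here, no measured compound compares those two groups directly, and that gap widens the range. A large step towards a higher number is therefore expected, of about the size seen for compound 1 at 2680 nM. The estimated change is a 20-fold higher number from compound 3 to compound 4 (1.30 log units; beyond the scatter). In this assay, compound 4 is estimated at 2000 nM, with an expected range of 600 nM to 7000 nM.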

Compound 4, half-maximal inhibitory concentration: 650 nM
Estimate against measurement, compound 4: 3.1-fold (0.49 log units) above, and the stated range covers the measured number.
By their numbers in this assay, from the lowest: compounds 3 and 2 (each within the scatter of the next); then compound 4; then compound 1.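

The propylamino group on the carbonyl carbon gives a number well below that of the benzylamino group, with a 4.1-fold lower number from compound 1 to compound 4 (0.62 log units; beyond the scatter) in this assay, so the group carried on the amide-type nitrogen still matters once that nitrogen is in place, and the ethyl-for-phenyl exchange on the saturated chain carbon is not silent. The aryl groups nonetheless keep the lower numbers, with a 6.5-fold higher number from compound 3 to compound 4 (0.81 log units; beyond the scatter) and a 5.4-fold higher number from compound 2 to compound 4 (0.73 log units; beyond the scatter); both steps are modest but beyond the scatter, and both are visibly smaller than the large steps seen earlier from compound 1 to the same two aryl compounds, so the loss on leaving the aryl groups depends on which amino group enters. No measured information on these compounds accounts for the difference between the propylamino and benzylamino groups.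

Open, from the compounds shown here alone, is whether the trend with the amino group follows chain length, as a methylamino or butylamino group would test, or whether a phenylamino group behaves like the aryl groups or like benzylamino. A plain butyl chain on the carbonyl carbon would also separate the effect of the added nitrogen from that of losing the aromatic ring.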